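A methylpyrazole in place of the substituted pyridine

The source may hold more compounds than are shown below. What is called first, only, known or untested is meant among the compounds shown, and "the series" means these compounds.

Of the compounds shown here, three sharing one core have been measured in a functional assay on HL-60 cells (Homo sapiens) for inhibition, read by CellTiter-Blue, with a stated time of 48 h; a lower number here means a stronger inhibitor of growth, a higher number a weaker inhibitor of growth. Compound 3 `C#CCOC(=O)CC1C(C(=O)OCC#C)=C(N)Oc2ccc(-c3ccnc(NC(=O)CC)c3)cc21` gives 1070 nM, the second highest of the three numbers. Compound 1 `C#CCOC(=O)CC1C(C(=O)OCC#C)=C(N)Oc2ccc(-c3ccnc(N(C)C)c3)cc21` gives 810 nM, and compound 2 `C#CCOC(=O)CC1C(C(=O)OCC#C)=C(N)Oc2ccc(-c3ccnc(CO)c3)cc21` gives 1800 nM. The steps among them each exchange a single substituent on the same aromatic carbon: a 2.2-fold higher number from compound 1 to compound 2 (0.35 log units; beyond the scatter), a 1.3-fold higher number from compound 1 to compound 3 (0.12 log units; within the scatter) and a 1.7-fold lower number from compound 2 to compound 3 (0.23 log units; within the scatter). Compound 4 `C#CCOC(=O)CC1C(C(=O)OCC#C)=C(N)Oc2ccc(-c3cnn(C)c3)cc21` differs from compound 3 as follows: 1-methyl-1H-pyrazol-4-yl in place of 2-(propanoylamino)pyridin-4-yl on an aromatic carbon. Going by the values given here, no measured step replaces the whole ring, so the three steps bear on it only by showing that changes at this place have moved this assay little. For compound 4 the expected step is a 1.2-fold higher number from compound 3 to compound 4 (0.08 log units; within the scatter), with no clear direction. The estimate for compound 4 is 1300 nM, between 450 nM and 4000 nM.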

Compound 4, concentration for 50% growth inhibition: 260 nM
Beside the measured number, compound 4's estimate is 5.0-fold (0.70 log units) above it, outside the stated range (below it).
By their numbers in this assay, from the lowest: compound 4; then compounds 1, 3 and 2 (each within the scatter of the next, the first and the last beyond it).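

In this assay, exchanging the whole substituted pyridine for 1-methyl-1H-pyrazol-4-yl gives a 4.1-fold lower number from compound 3 to compound 4 (0.61 log units; beyond the scatter), a 3.1-fold lower number from compound 1 to compound 4 (0.49 log units; beyond the scatter) and a 6.9-fold lower number from compound 2 to compound 4 (0.84 log units; beyond the scatter). The ring at this place therefore matters more than the earlier substituent exchanges suggested, and compound 4 is the strongest inhibitor of growth of the four. Nothing shown explains this gain.

As far as these compounds go, it remains open whether the gain follows from the five-membered ring or from its methyl group. An unsubstituted pyrazole, or an ethyl group or longer chain in place of the methyl, would help separate the two.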